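Swapping tert-Butyl for Cyclopropyl on the Amide Carbonyl

The source may hold more compounds than are shown below. What is called first, only, known or untested is meant among the compounds shown, and "the series" means these compounds.

Compound 1 `CSCC(=O)N1CCN(c2nc(=O)c3cc(C(F)(F)F)cc([N+](=O)[O-])c3s2)CC1`: 15.2 ug/mL
Compound 2 `CC(=O)N1CCN(c2nc(=O)c3cc(C(F)(F)F)cc([N+](=O)[O-])c3s2)CC1`: 83.9 ug/mL
Compound 3 `CC(C)(C)C(=O)N1CCN(c2nc(=O)c3cc(C(F)(F)F)cc([N+](=O)[O-])c3s2)CC1`: 5.87 ug/mL

In a physicochemical assay for solubility, read by HPLC (a higher number here means a more soluble compound, a lower number a less soluble compound), compound 3 stands lowest of the three, with a 2.6-fold lower number from compound 1 to compound 3 (0.41 log units; beyond the scatter) and a 14-fold lower number from compound 2 to compound 3 (1.16 log units; beyond the scatter). Compound 4 `O=C(C1CC1)N1CCN(c2nc(=O)c3cc(C(F)(F)F)cc([N+](=O)[O-])c3s2)CC1` differs from compound 3 in one place: cyclopropyl in place of tert-butyl on a carbonyl carbon. Both measured steps at this carbonyl bear on the change: going from methyl to tert-butyl gave a 14-fold lower number from compound 2 to compound 3 (1.16 log units; beyond the scatter), and from (methylsulfanyl)methyl to tert-butyl gave a 2.6-fold lower number from compound 1 to compound 3 (0.41 log units; beyond the scatter). In each, the group with more heavy atoms entered and the number fell. Here the direction reverses, so a modest rise is expected, short of compound 2, since cyclopropyl is not methyl. For compound 4 the expected step is a 3.4-fold higher number from compound 3 to compound 4 (0.53 log units; beyond the scatter). Compound 4 is estimated at 20 ug/mL, ranging from 8 ug/mL to 50 ug/mL.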

Compound 4, solubility: 52.9 ug/mL
Beside the measured number, compound 4's estimate is 2.6-fold (0.42 log units) below it, and the stated range ends below it.
By their numbers in this assay, from the lowest: compound 3; then compound 1; then compounds 4 and 2 (each within the scatter of the next).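

In this assay, replacing tert-butyl with cyclopropyl on this carbonyl carbon gives a 9.0-fold higher number from compound 3 to compound 4 (0.95 log units; beyond the scatter), and replacing (methylsulfanyl)methyl with it gives a 3.5-fold higher number from compound 1 to compound 4 (0.54 log units; beyond the scatter). Replacing methyl with cyclopropyl gives a 1.6-fold lower number from compound 2 to compound 4 (0.20 log units; within the scatter), so compound 4 shows that a group with more heavy atoms than methyl need not lower the number here, although compound 1 and compound 3 do follow that trend. Nothing measured here explains these steps. Going by these compounds, it remains open whether cyclobutyl, a longer carbon chain, or a chain carrying an amine or a carboxylic acid would give a similar number at this carbonyl carbon.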